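Removing a Hydroxymethyl Group: an Expected Rise in Lipophilicity

A few compounds are considered here, and "the series" means these few. Any claim that something is new, unique, unknown or untested is made for them only; others in the source may bear on it.

Three compounds have so far been measured in a physicochemical assay for lipophilicity, at pH 7.4; on this read-out lower numbers stand for lower lipophilicity and higher numbers for higher lipophilicity:

Compound 1, `Cc1cc(S(=O)(=O)N2CCC[C@@H]2c2ccc(F)cc2)cc(C)c1F`: 4.4
Compound 2, `Cc1cc(S(=O)(=O)N2[C@H](CO)CC[C@@H]2c2ccc(F)cc2)cc(C)c1F`: 3.3
Compound 3, `O=S(=O)(c1cc(Cl)c(F)c(Cl)c1)N1[C@H](CO)CC[C@@H]1c1ccc(F)cc1`: 3.8

Compound 2 and compound 1 share a core and differ in one place only: hydrogen in place of hydroxymethyl on a saturated ring carbon. In this assay that change produced a number 1.10 log units higher from compound 2 to compound 1 (beyond the scatter), a step well beyond the scatter of the measurement.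

Compound 3 rests on a different core; the difference between the two cores of compound 2 and compound 3 is not broken down here. In this assay compound 3 gives 3.8, which places it between compound 2 and compound 1, separated from each of them by more than the usual scatter.

Compound 4, `O=S(=O)(c1cc(Cl)c(F)c(Cl)c1)N1CCC[C@@H]1c1ccc(F)cc1`, has not yet been measured. It stands to compound 3 exactly as compound 1 stands to compound 2: hydrogen in place of hydroxymethyl on a saturated ring carbon. The place of the change is described in the same words for both pairs, so this is the same change made on the second core.

Compound 4 is therefore expected to lie above compound 3 by about a number 1.10 log units higher from compound 3 to compound 4 (beyond the scatter), a step set beside a number 1.10 log units higher from compound 2 to compound 1 (beyond the scatter). This expectation rests on that single earlier occurrence of the change, so it carries real uncertainty, and the second core has been seen only once. For compound 4 the estimated value in this assay is 4.9, expected to fall between 4.5 and 5.3.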

Compound 4, distribution coefficient: 4.6
Compound 4: middle estimate off by 0.30 log units, on the high side, and the stated range covers the measured number.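

On the second core the change again raised the number in this assay: the new step is a number 0.80 log units higher from compound 3 to compound 4 (beyond the scatter) and the earlier one on the first core is a number 1.10 log units higher from compound 2 to compound 1 (beyond the scatter), so hydrogen in place of hydroxymethyl on a saturated ring carbon went the same way on both cores and beyond the scatter each time. That is the whole of the pattern, drawn from two matched pairs: it shows that the direction carried over from one core to the other, but it does not show that the size of the step is fixed, whether the two sizes truly differ, or what the step would be on a third core. Nothing at hand bears on why the step came out as it did on either core.

The compounds shown compare only hydrogen and hydroxymethyl at this ring carbon, which leaves open how a longer chain such as hydroxyethyl, an amine such as aminomethyl, or a carboxylic acid would read there. They also leave open whether the upward step would hold on any core other than those of compound 1 and compound 4, or with a change at another place on the ring.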